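A Single Halogen Change and Its Expected Effect

The source may report more compounds than this note shows. Statements on the series, on what has been measured and on what is new or still open speak of the compounds shown alone.

Within the data shown here, in an assay on isolated protein for inhibition of aldehyde dehydrogenase 1A1 (Homo sapiens), read by spectrophotometry, tested at 10 uM (a lower number here means less inhibition, a higher number more inhibition at the concentration tested (going by the name of the read-out)), compound 1 `Cc1cccc(Cn2c(CN3CCN(C(=O)c4ccc(C(F)(F)F)cc4)CC3)nc3ccccc32)c1` gives 22.9%, the lowest of the three numbers known, though both other numbers lie within the usual scatter of it. Compound 2 `CC(C)CCn1c(OC2CCN(C(=O)c3ccco3)CC2)nc2ccccc21` gives 30.8% in this assay, and compound 3 `O=C(C1CC1)N1CCN(Cc2nc3ccccc3n2Cc2ccc(F)cc2)CC1` gives 32.7%. Compound 4 `Cc1cccc(Cn2c(CN3CCN(C(=O)c4ccc(F)cc4)CC3)nc3ccccc32)c1` differs from compound 1 in one place: fluoro in place of trifluoromethyl on an aromatic carbon. Among the measured compounds shown here, no pair of measured compounds that differ in a single place is available, so this change has no measured precedent here. Because compound 1 gives 22.9% and all three numbers sit close together, only a small step is expected, a number 2.1 percentage points higher from compound 1 to compound 4 (within the scatter), likely not beyond the scatter in either direction. Compound 4 is therefore estimated at 25%, with a range from 8% to 42%.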

Compound 4, a percentage reported as inhibition, at one concentration (the size of the read-out at that concentration, not a potency): 27.1%
For compound 4 the middle estimate is 2.1 percentage points below the measured one, within the range that was stated.
By their numbers in this assay, from the lowest: compounds 1, 4, 2 and 3 (each within the scatter of the next).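

Fluoro in place of trifluoromethyl on the aromatic carbon gives the only single-place comparison in this assay: a number 4.2 percentage points higher from compound 1 to compound 4 (within the scatter). Among these compounds, for this one pair, going from 4-(trifluoromethyl)phenyl to 4-fluorophenyl therefore produces no step that can be told from the scatter. No outside evidence bears on this result.

Whether any group at this place can move the number beyond the scatter stays open, as neither an amine nor a carboxylic acid on this aromatic carbon is among the compounds shown. As far as these compounds go, it also remains open whether the same change reads alike on another core.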